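The compounds below may be only part of what the source reports. "The series", "measured", "known", "first", "only" and "open" are said of these compounds alone.

In an assay on isolated protein for inhibition of DNA nucleotidylexotransferase (Homo sapiens), read by scintillation counting, with a stated time of 10 min (on this read-out lower numbers stand for stronger inhibition and higher numbers for weaker inhibition), compound 1, whose structure is `CCOC(=O)C(=O)CC(=O)/C=C/c1cn(Cc2ccc(F)cc2)c2ccccc12`, gives only a limit, > 40 uM. Compound 2, `CCOC(=O)C(=O)CC(=O)/C=C/c1cn(Cc2ccc(C#N)cc2)c2ccccc12`, differs from it by cyano in place of fluoro on an aromatic carbon. In this assay compound 2 also gives only a limit, > 40 uM. The step that the two limits leave unreadable from compound 1 to compound 2 therefore cannot be read, since both values sit at the limit; the evidence here is simply (the limit of > 40 uM in this assay, at which 3 of the 3 values shown sit).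

Compound 3 has the structure `CCOC(=O)C(=O)CC(=O)/C=C/c1cc(C(=O)c2ccccc2)cn1Cc1ccc(F)cc1`; how its core differs from the core of compound 1 is not broken down here. In this assay compound 3 likewise gives only a limit, > 40 uM.

Compound 4, `CCOC(=O)C(=O)CC(=O)/C=C/c1cc(C(=O)c2ccccc2)cn1Cc1ccc(C#N)cc1`, is to be measured. It differs from compound 3 by cyano in place of fluoro on an aromatic carbon, the same kind of change as that from compound 1 to compound 2. Within the data shown here, since three of three values sit at the limit, the account expects compound 4 to behave in the same way, with an expected step that the limit leaves unreadable from compound 3 to compound 4 from compound 3, resting on the fact that the limit of > 40 uM in this assay, at which 3 of the 3 values shown sit, holds for every compound so far. Compound 4 is thus estimated at about 60 uM in this assay, within an expected range of 25 uM to 250 uM.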

Compound 4, concentration for 50% inhibition: > 40 uM
Compound 4 gave a limit, no number; the forecaster's own chance of this, stated with the estimate: 85%; the middle value does not contradict the limit.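

In this assay compound 4 gives > 40 uM as a limit and not a number, so no step can be read from compound 3 to compound 4: (the limit of > 40 uM in this assay, at which 4 of the 4 values shown sit). The compounds shown leave open how strongly any of them inhibits, and whether exchanging fluoro for cyano changes inhibition on either core.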